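A few compounds are considered here, and "the series" means these few. Any claim that something is new, unique, unknown or untested is made for them only; others in the source may bear on it.

For the measured compounds named here, in an assay on membranes from liver for displacement of a labelled ligand from Sigma intracellular receptor 2 (Rattus norvegicus), read by scintillation counting, with a stated time of 120 min (on this read-out higher numbers stand for weaker inhibition and lower numbers for stronger inhibition), compound 2 `C[C@H]1CN(CCCCc2ccccc2)CCCN1Cc1ccccc1` gives 8.6 nM, the lowest of the two numbers measured so far. The nearest is compound 1 `COc1ccc(CN2CCCN(Cc3ccccc3)[C@@H](C)C2)cc1`, which in this assay gives 46 nM, a higher number and a gap beyond the usual scatter. Compound 3 `C[C@@H]1CN(CCCCc2ccccc2)CCCN1Cc1ccccc1` has not yet been measured. It differs from compound 2 in one respect only: the two compounds have the same atoms and bonds and differ only in configuration as drawn: 1 of 1 stereo elements differ; a stereocentre at a saturated ring carbon is drawn S in compound 2 and R in compound 3. Going by the values given here, no step between measured compounds shows what such a change does here. For compound 3 a modest rise in the number, in the direction of weaker inhibition, is expected, a 1.7-fold higher number from compound 2 to compound 3 (0.24 log units; within the scatter). Compound 3 is therefore estimated at 15 nM, within a range from 4 nM to 60 nM.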

Compound 3, inhibition constant: 71 nM
Compound 3: middle estimate off by 4.7-fold (0.68 log units), on the low side; the whole stated range lies below it.
By their numbers in this assay, from the lowest: compound 2; then compounds 1 and 3 (each within the scatter of the next).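

In this assay, for the compounds shown here, switching the saturated ring carbon from S to R gives an 8.3-fold higher number from compound 2 to compound 3 (0.92 log units; beyond the scatter), so the configuration at this position clearly matters, which the earlier compounds could not show. The gap can be assigned to this stereocentre alone for one simple reason: the fact that compounds 2 and 3 differ only in the configuration as drawn

From the compounds shown here alone, compound 1 appears in only one configuration, so it remains open whether the same preference holds with its different groups on the ring nitrogens. Going by these compounds, it is also open how an ethyl group at this ring carbon would behave in either configuration.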